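Cytotoxicity notes on a phenyl-substituted series

A few compounds are considered here, and "the series" means these few. Any claim that something is new, unique, unknown or untested is made for them only; others in the source may bear on it.

Measured so far:
compound 1 `Cc1cc(-c2ccccc2)cc(C)c1Oc1cc(N)nc(Nc2ccc(C#N)cc2)n1`: 25600 nM
compound 2 `Cc1cc(-c2ccccc2F)cc(C)c1Oc1cc(N)nc(Nc2ccc(C#N)cc2)n1`: 29300 nM
compound 3 `Cc1cc(-c2ccc(Cl)cc2)cc(C)c1Oc1cc(N)nc(Nc2ccc(C#N)cc2)n1`: 21500 nM

In a toxicity assay on MT4 cells (Homo sapiens) for cytotoxicity, read by MTT assay (a lower number here means that less compound is tolerated, a higher number that more compound is tolerated), compound 1 gives 25600 nM, the second highest of the three numbers, with all three lying within the scatter of one another. The changes examined so far sit on the pendant phenyl: a 1.1-fold higher number from compound 1 to compound 2 (0.06 log units; within the scatter) and a 1.2-fold lower number from compound 1 to compound 3 (0.08 log units; within the scatter) were both within the scatter, as was a 1.4-fold lower number from compound 2 to compound 3 (0.13 log units; within the scatter). Neither fluoro nor chloro on that ring moved the tolerated concentration.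

Compound 4 `COc1ccccc1-c1cc(C)c(Oc2cc(N)nc(Nc3ccc(C#N)cc3)n2)c(C)c1` differs from compound 1 by methoxy in place of hydrogen on an aromatic carbon. For the measured compounds named here, it is a further substituent on the same pendant phenyl, and the steps that bear on it are the fluoro and chloro steps from compound 1, both flat. No step beyond the scatter in this assay is therefore expected in either direction. For compound 4 the expected value is 25000 nM, with a range from 12000 nM to 50000 nM. For compound 4 this expectation amounts to a 1.0-fold lower number from compound 1 to compound 4 (0.01 log units; within the scatter).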

Compound 4, half-maximal cytotoxic concentration: 21800 nM
For compound 4 the middle estimate is 1.1-fold (0.06 log units) above the measured one, and the stated range covers the measured number.
By their numbers in this assay, from the lowest: compounds 3, 4, 1 and 2 (each within the scatter of the next).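

Methoxy, ortho to a large group on the pendant phenyl, brings in 2 heavy atoms and 1 hydrogen-bond acceptor, yet in this assay the change stays flat: a 1.2-fold lower number from compound 1 to compound 4 (0.07 log units; within the scatter). Set against the halogen-bearing compounds, it is just as flat, with a 1.3-fold lower number from compound 2 to compound 4 (0.13 log units; within the scatter) and a 1.0-fold higher number from compound 3 to compound 4 (0.01 log units; within the scatter), so this position has now tolerated a group containing oxygen as well as fluoro and chloro without a step beyond the scatter. No supporting measurement is available to account for this flatness.

As far as these compounds go, whether an amine or a carboxylic acid on this ring, or a longer chain in place of methoxy, would produce a step beyond the scatter remains open. Also open, from the compounds shown here alone, is whether methoxy elsewhere on the pendant phenyl would read the same.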